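This account rests on a few compounds, and the source may have more. Where it says the series, first, only, none or still open, it means among the compounds named here.

Measured in a functional assay on A549 cells (Homo sapiens) for cytotoxicity, read by MTT assay, with a stated time of 68 h; a lower number here means a stronger inhibitor, a higher number a weaker inhibitor:
compound 1, `O=C(Nc1cccc(-c2cccc(NC(=O)C(Cl)Cl)c2)c1)C(Cl)Cl`: 47900 nM
compound 2, `COc1ccc(-c2cccc(NC(=O)C(Cl)Cl)c2)cc1`: 8530 nM
compound 3, `O=C(Nc1cc(-c2ccc(OC3CCCCO3)cc2)cc(-c2ccc(OC3CCCCO3)cc2)c1)C(Cl)Cl`: 2750 nM

Compound 1 stands at the highest of the three numbers in this assay. Compound 2 is its nearest neighbour and compound 3 the furthest; both lie beyond the scatter of repeated measurements, so compound 1 is the weakest of the measured set. Among the measured compounds shown here, no pair among the measured compounds differs in one place only, so no single step has yet been read directly.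

Compound 4, `Cc1cccc(-c2cccc(NC(=O)C(Cl)Cl)c2)c1`, is not yet measured. It differs from compound 1 by methyl in place of ((dichloromethyl)carbonyl)amino on an aromatic carbon. For the measured compounds named here, the only measured guide is compound 2, which keeps a single ((dichloromethyl)carbonyl)amino group on the shared core and gives 8530 nM. On that basis the expected step is a 4.8-fold lower number from compound 1 to compound 4 (0.68 log units; beyond the scatter), a fall beyond the scatter, with wide uncertainty because only compound 2 gives 8530 nM as a comparison. Compound 4 is estimated at 10000 nM, within 3000 nM to 35000 nM.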

Compound 4, half-maximal inhibitory concentration: 8700 nM
For compound 4 the middle estimate is 1.1-fold (0.06 log units) above the measured one, within the range that was stated.
By their numbers in this assay, from the lowest: compound 3; then compounds 2 and 4 (each within the scatter of the next); then compound 1.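

In this assay, methyl in place of ((dichloromethyl)carbonyl)amino on an aromatic carbon gives a 5.5-fold lower number from compound 1 to compound 4 (0.74 log units; beyond the scatter), the first single change read directly in this series. At this position, the second ((dichloromethyl)carbonyl)amino group of compound 1 is therefore not required for the measured cytotoxicity, and a single carbon group in its place gives a modest gain beyond the scatter. No supporting measurement bears on the reason for this step.

Among the compounds shown here, the single step leaves open whether the fall follows the loss of the ((dichloromethyl)carbonyl)amino group or the arrival of methyl. A plain hydrogen at this place would separate those two readings, while an amine or a carboxylic acid there would show how far the step extends beyond methyl.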